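The source may report more compounds than this note shows. Statements on the series, on what has been measured and on what is new or still open speak of the compounds shown alone.

Measured so far:
compound 1 `CCc1cc(C(C)=O)c(O)cc1OCCCCCCCC(C)(C)C#N`, in an assay on isolated protein for inhibition of leukotriene B4 receptor 1 (Homo sapiens), tested at 10 uM (a higher number here means more inhibition at the concentration tested (going by the name of the read-out), a lower number less inhibition), giving 66%;
compound 2 `CCc1cc(C(C)=O)c(O)cc1OCCCCCC(C)(C)c1nnnn1C`, in this assay giving 99%.

Compound 2 stands highest of these two numbers. Within the data shown here, the single measured step, a number 33 percentage points higher from compound 1 to compound 2 (beyond the scatter), shows that changing the group at the end of the chain moved the result far beyond the scatter. Compound 3 `CCc1cc(C(C)=O)c(O)cc1OCCCCCn1cncn1` carries a different change at that same place: 1H-1,2,4-triazol-1-yl in place of 1-methyl-1-(1-methyl-1H-tetrazol-5-yl)ethyl on a saturated chain carbon, five bonds along the chain from an oxygen on an aromatic ring. Among the measured compounds shown here, no measured step covers this exact swap, so the direction is uncertain; a moderate drop of a number 29 percentage points lower from compound 2 to compound 3 (beyond the scatter) is expected. Compound 3 is estimated at 70%, within 35% to 95%.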

Compound 3, a percentage reported as inhibition, at one concentration (the size of the read-out at that concentration, not a potency): 82%
Estimate against measurement, compound 3: 12 percentage points below; low and high end bracket the measured number.
By their numbers in this assay, from the lowest: compound 1; then compound 3; then compound 2.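

Compound 3 shows that the full 1-methyl-1-(1-methyl-1H-tetrazol-5-yl)ethyl group is not needed for a high number in this assay: 1H-1,2,4-triazol-1-yl, with fewer heavy atoms, gives a number 17 percentage points lower from compound 2 to compound 3 (beyond the scatter) and so retains much of the inhibition. The same group also gives a number 16 percentage points higher from compound 1 to compound 3 (beyond the scatter) against the 3-cyano-3-methylbutyl end. Among these three compounds, both ending in a five-membered aromatic ring stand above the one ending in a nitrile.

Going by these compounds, whether a carboxylic acid or an amine at this chain end would do as well remains open. Nothing shown here explains these differences.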